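Working notes: compound 3, furan-2-yl in place of the aryl group

The source may report more compounds than this note shows. Statements on the series, on what has been measured and on what is new or still open speak of the compounds shown alone.

Measured so far:
compound 1 `C=C1CC[C@@H]2[C@](C)(CO)[C@H](O)CC[C@@]2(C)[C@@H]1/C=C/C1=C/C(=C/c2ccccc2)OC1=O` gives 58000 nM
compound 2 `C=C1CC[C@@H]2[C@](C)(CO)[C@H](O)CC[C@@]2(C)[C@@H]1/C=C/C1=C/C(=C/c2ccc(N(C)C)cc2)OC1=O` gives 70000 nM

Both numbers come from an assay on isolated protein for inhibition of Maltase-glucoamylase (Homo sapiens); a lower number here means a stronger inhibitor, a higher number a weaker inhibitor. Compound 2 stands highest of the two numbers, with compound 1 nearest; the step of a 1.2-fold higher number from compound 1 to compound 2 (0.08 log units; within the scatter) lies within the scatter, so no order between the two is read from it.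

Compound 3 `C=C1CC[C@@H]2[C@](C)(CO)[C@H](O)CC[C@@]2(C)[C@@H]1/C=C/C1=C/C(=C/c2ccco2)OC1=O` differs from compound 2 by furan-2-yl in place of 4-(dimethylamino)phenyl on a double-bonded chain carbon bound to a double-bonded ring carbon. For the measured compounds named here, the only measured step that bears on this position is a 1.2-fold higher number from compound 1 to compound 2 (0.08 log units; within the scatter), where dimethylamino replaced hydrogen on the ring without a shift beyond the scatter. Going by the values given here, no measured step exchanges the ring itself, so the move to furan-2-yl rests on that one neighbouring change alone. The expectation is that compound 3 stays in the same region, with a 1.2-fold lower number from compound 2 to compound 3 (0.07 log units; within the scatter) within the scatter. The estimate for compound 3 in this assay is 60000 nM, range 25000 nM to 150000 nM.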

Compound 3, half-maximal inhibitory concentration: 100000 nM
Beside the measured number, compound 3's estimate is 1.7-fold (0.22 log units) below it; the range from low to high includes it.
By their numbers in this assay, from the lowest: compounds 1, 2 and 3 (each within the scatter of the next).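

In this assay, exchanging the ring itself for furan-2-yl on the double-bonded chain carbon gives a 1.4-fold higher number from compound 2 to compound 3 (0.15 log units; within the scatter) and also a 1.7-fold higher number from compound 1 to compound 3 (0.24 log units; within the scatter) as its second reading. Earlier, only a substituent on the phenyl ring had been varied; now a six-membered aromatic ring of carbon only and a five-membered aromatic ring with a hetero atom also fall within the scatter of each other, so no order among the three compounds can be read and no ring preference is visible at this position. No evidence accompanies these numbers that could account for them.

Still open, on these data alone, is whether any group at this carbon moves the number beyond the scatter, for instance a carboxylic acid on the phenyl ring or a longer alkyl chain in place of the ring. The shared core stays constant throughout, so the contribution of its hydroxyl groups remains unread.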